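Replacing the indolyl group: expectation for compound 3

The source may hold more compounds than are shown below. What is called first, only, known or untested is meant among the compounds shown, and "the series" means these compounds.

Measured so far in a functional assay on U-87MG ATCC cells (Homo sapiens) for cytotoxicity, read by MTT assay, with a stated time of 72 h; a higher number here means a weaker inhibitor, a lower number a stronger inhibitor:
compound 1 `CN(C)CCn1cnnc1-c1cc(Oc2ccc(NC(=O)N/N=C/c3c[nH]c4ccccc34)cc2F)ccn1` gives 690 nM
compound 2 `CN(C)CCn1cnnc1-c1cc(Oc2ccc(NC(=O)N/N=C/c3cccc(Cl)c3Cl)cc2F)ccn1` gives 13200 nM

Compound 1 stands lowest of the two numbers; compound 2 is its nearest neighbour, and the step of a 19-fold higher number from compound 1 to compound 2 (1.28 log units; beyond the scatter) lies beyond the scatter. The shared core is kept throughout.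

Compound 3 `CN(C)CCn1cnnc1-c1cc(Oc2ccc(NC(=O)N/N=C/c3cc(Br)c(O)c(Br)c3)cc2F)ccn1` has not yet been measured. Its change from compound 1 is 3,5-dibromo-4-hydroxyphenyl in place of 1H-indol-3-yl on a carbon with a double bond to nitrogen.

Among the compounds with values here, only one measured step bears on this: a 19-fold higher number from compound 1 to compound 2 (1.28 log units; beyond the scatter), which also exchanged the 1H-indol-3-yl on the carbon with a double bond to nitrogen for a six-membered carbon ring, and gave a large rise. The 3,5-dibromo-4-hydroxyphenyl differs from 2,3-dichlorophenyl in its one hydrogen-bond donor and one acceptor, so the data cannot fix how closely compound 3 will track compound 2. A clear rise is expected, estimated as a 7.2-fold higher number from compound 1 to compound 3 (0.86 log units; beyond the scatter), somewhat smaller than the step to compound 2 but well beyond the scatter. Compound 3 is expected to give 5000 nM, in the range 1500 nM to 16000 nM.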

Compound 3, half-maximal inhibitory concentration: > 100000 nM
Compound 3: only a limit was reported (the forecaster's own chance of this, stated with the estimate: 5%); at least 20-fold (1.30 log units) between middle value and limit.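

In this assay compound 3 carries only a limit, not a number: the limit of > 100000 nM in this assay, at which 1 of the 3 values shown sits. With the 3,5-dibromo-4-hydroxyphenyl group on the carbon with a double bond to nitrogen, the series shows an at least 140-fold higher number from compound 1 to compound 3 (2.16 log units; beyond the scatter), so a second replacement of the 1H-indol-3-yl also raises the number, and by more than the first. The step of an at least 7.5-fold higher number from compound 2 to compound 3 (0.87 log units; beyond the scatter) adds what compound 2 alone could not show: the two substituted phenyl groups are not interchangeable at this place, and the substituents on the six-membered ring matter as well as the loss of the 1H-indol-3-yl.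

As far as these compounds go, whether the hydroxyl or the two bromines account for the gap to compound 2 stays open, and the limit hides how far compound 3 actually lies from it. An unsubstituted phenyl or a phenyl carrying only the hydroxyl at this place would separate these contributions.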